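From Chloro to Bromo at Compound 3

This account rests on a few compounds, and the source may have more. Where it says the series, first, only, none or still open, it means among the compounds named here.

Of the compounds shown here, three sharing a core have been measured in a functional assay on A549 cells (Homo sapiens) for inhibition, read by MTT assay, with a stated time of 72 h; on this read-out lower numbers stand for stronger inhibition and higher numbers for weaker inhibition. In this read-out, compound 1 (`Cc1cc2occ(-c3nc(-c4ccccc4)c(-c4ccccc4)n3-c3ccc(Cl)c(Cl)c3)c(=O)c2cc1Cl`) gives 6250 nM, compound 2 (`Cc1ccc(-n2c(-c3coc4cc(C)c(Cl)cc4c3=O)nc(-c3ccccc3)c2-c2ccccc2)c(C)c1`) gives 6250 nM and compound 3 (`Cc1cc2occ(-c3nc(-c4ccccc4)c(-c4ccccc4)n3-c3ccc(Cl)cc3)c(=O)c2cc1Cl`) gives 12500 nM. On these numbers, compound 3 stands within the usual scatter of both other compounds.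

The next compound, compound 4 (`Cc1cc2occ(-c3nc(-c4ccccc4)c(-c4ccccc4)n3-c3ccc(Br)cc3)c(=O)c2cc1Cl`), differs from compound 3 in one place: bromo in place of chloro on an aromatic carbon. This puts bromo in place of chloro on an aromatic carbon, para to a large group, turning 4-chlorophenyl into 4-bromophenyl.

Two measured steps alter the same group on the aromatic nitrogen: a 2.0-fold higher number from compound 1 to compound 3 (0.30 log units; within the scatter) and a 2.0-fold higher number from compound 2 to compound 3 (0.30 log units; within the scatter). Both lie within the scatter, as does no change at the digits printed from compound 1 to compound 2 (within the scatter). None of these steps exchanges one halogen for another, so the data offer no direct test of bromo, only the evidence of these small steps at this group.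

On the strength of those steps, the expected move in this assay stays within the scatter, and the estimated step is a 1.3-fold lower number from compound 3 to compound 4 (0.10 log units; within the scatter). For compound 4 the expected value is 10000 nM, with an estimated range of 5000 nM to 20000 nM.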

Compound 4, half-maximal inhibitory concentration: 25000 nM
Estimate against measurement, compound 4: 2.5-fold (0.40 log units) below, outside the stated range (above it).
By their numbers in this assay, from the lowest: compounds 1, 2, 3 and 4 (each within the scatter of the next, the first and the last beyond it).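

In this assay, going by these compounds alone, bromo in place of chloro on an aromatic carbon, para to a large group, gives a 2.0-fold higher number from compound 3 to compound 4 (0.30 log units; within the scatter) and so offers the first direct halogen exchange at this position, one that does not separate the two halogens. Compared with the substituted phenyl groups on the aromatic nitrogen of the other two compounds, the 4-bromophenyl group gives a 4.0-fold higher number from compound 2 to compound 4 (0.60 log units; beyond the scatter) and a 4.0-fold higher number from compound 1 to compound 4 (0.60 log units; beyond the scatter) as the first steps at this nitrogen to pass beyond the scatter, though both are modest and compound 3 remains within the scatter of all three other compounds. No measured evidence bears on what lies behind these numbers.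

The compounds shown carry only chloro, bromo and methyl groups on this phenyl ring, which leaves open how an amine or a carboxylic acid at the same place would read in this assay. Going by these compounds, it also remains open whether the exchange of chloro for bromo would read the same way with a second group on the ring, as in the 3,4-dichlorophenyl group of compound 1.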